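Replacing 4-fluorophenyl with 3-chlorophenyl on compound 3

The source may hold more compounds than are shown below. What is called first, only, known or untested is meant among the compounds shown, and "the series" means these compounds.

The values below come from a functional assay on Gurav cells (Homo sapiens) for inhibition, read by sulforhodamine B assay (on this read-out lower numbers stand for stronger inhibition of growth and higher numbers for weaker inhibition of growth), and cover three compounds.

Compound 1 `COc1cc(-c2ccc(-c3ccc(-c4nc5cc(C)ccc5[nH]4)cc3)cc2)cc(OC)c1OC` gives 170 nM
Compound 2 `Fc1ccc(-c2ccc(-c3ccc(-c4nc5ccccc5[nH]4)cc3)cc2)cc1` gives 100000 nM
Compound 3 `Oc1cccc2[nH]c(-c3ccc(-c4ccc(-c5ccc(F)cc5)cc4)cc3)nc12` gives 2860 nM

Among these three numbers compound 3 stands in the middle, with compound 1 lower and compound 2 higher. The next compound is compound 4 `Oc1cccc2[nH]c(-c3ccc(-c4ccc(-c5cccc(Cl)c5)cc4)cc3)nc12` and it has yet to be measured in this assay by the same read-out. It departs from compound 3 in one place, 3-chlorophenyl in place of 4-fluorophenyl on an aromatic carbon and the rest of the structure stays the same. Within the data shown here, the only measured step between compounds differing in one place is a 35-fold lower number from compound 2 to compound 3 (1.54 log units; beyond the scatter) and it is large. That step, however, comes from hydroxy in place of hydrogen on an aromatic carbon, a change that compound 4 does not repeat. Among the measured compounds shown here, no measured step touches the 4-fluorophenyl group, so the data give no direct size for this swap. Compound 1 differs from compound 3 in more than one place and offers no clean comparison. With nothing pointing either way, no shift beyond the scatter is expected in this assay for this swap. The expected step is a 1.1-fold lower number from compound 3 to compound 4 (0.06 log units; within the scatter) and it remains an uncertain estimate. For compound 4 the value is estimated at 2500 nM within a range from 700 nM to 9000 nM as the expected span.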

Compound 4, concentration for 50% growth inhibition: 2310 nM
The estimate for compound 4 lay 1.1-fold (0.03 log units) above the measured number; the range from low to high includes it.
By their numbers in this assay, from the lowest: compound 1; then compounds 4 and 3 (each within the scatter of the next); then compound 2.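

In this assay, 3-chlorophenyl in place of 4-fluorophenyl gives a 1.2-fold lower number from compound 3 to compound 4 (0.09 log units; within the scatter), so the two structures cannot be told apart on this read-out. Among these compounds, this is the first measured step to touch the 4-fluorophenyl group, and it shows that, with the hydroxy group kept, this place on the aromatic ring can take a different halogen in a different ring position without a shift beyond the scatter, in contrast to the large change seen with the hydroxy group in a 35-fold lower number from compound 2 to compound 3 (1.54 log units; beyond the scatter). No measurement at hand bears on why the number holds where it does.

What the compounds shown leave open is how much of this small step belongs to the change of halogen and how much to its change of ring position, since the two changed together and may offset each other. They also leave open whether an amine or a carboxylic acid on this same aromatic ring would keep the number within the scatter or move it well beyond.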